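From compound 2 to compound 3: one added methoxy

This account rests on a few compounds, and the source may have more. Where it says the series, first, only, none or still open, it means among the compounds named here.

Compound 1 `COC(=O)c1c(-c2ccc(OCc3ccccc3)cc2)oc2ccc(OC)cc2c1=O`: 22.1 ug/mL
Compound 2 `COC(=O)c1c(-c2ccc(O)cc2)oc2ccccc2c1=O`: > 25 ug/mL

Both compounds were tested in a functional assay on A549 cells (Homo sapiens) for cytotoxicity, read by MTT assay, with a stated time of 6 days (on this read-out lower numbers stand for an effect already at smaller amounts and higher numbers for an effect only at larger amounts of compound), and share one core. For compound 2 the result > 25 ug/mL is a limit and not a number.

Compound 3 `COC(=O)c1c(-c2ccc(O)cc2)oc2ccc(OC)cc2c1=O` has not yet been measured. It arises from compound 2 by a single change methoxy in place of hydrogen on an aromatic carbon of a six-membered aromatic ring of carbon only, part of a fused or bridged system of two rings.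

Compound 1 also carries this methoxy, though it differs from compound 3 elsewhere, and compound 1 gives 22.1 ug/mL in this assay. On that basis a small shift toward lower numbers is expected, an estimated at least 1.1-fold lower number from compound 2 to compound 3 (0.07 log units; that floor lies within the scatter) that may not exceed the usual scatter. Compound 3 is estimated at 21 ug/mL with a range from 11 ug/mL to 35 ug/mL on this read-out.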

Compound 3, concentration for half-maximal effect: > 25 ug/mL
Compound 3: no number, only a limit; the forecaster's own chance of this, stated with the estimate: 45%; middle value at least 1.1-fold (0.07 log units) away from the limit.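

In this assay the methoxy on the aromatic carbon gives no readable step, because compound 2 and compound 3 both stop at the same limit, which is not a number: the limit of > 25 ug/mL in this assay, at which 2 of the 3 values shown sit.

Going by these compounds alone, with the methoxy held in common, hydrogen in place of benzyl on the oxygen gives an at least 1.1-fold higher number from compound 1 to compound 3 (0.05 log units; that floor lies within the scatter), so the one numbered value now has a partner that differs from it in a single place. The methoxy alone did not bring compound 3 off the limit.

On these data alone, how far beyond the limit compound 2 and compound 3 truly lie remains open, as does whether the benzyl step exceeds the usual scatter. Also open, as far as these compounds go, is what an amine or a longer chain would give in place of the methoxy on the same aromatic carbon.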